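The source may report more compounds than this note shows. Statements on the series, on what has been measured and on what is new or still open speak of the compounds shown alone.

Within the data shown here, the compounds measured so far are compound 1 `O=C1C=C(Nc2ccc(I)cc2)C(=O)c2c1nc1n2[C@H]2OC[C@@H](O)[C@H]2OC1` with 2300 nM, compound 2 `O=C1C(Nc2cccc(Cl)c2)=CC(=O)c2c1nc1n2[C@H]2OC[C@@H](O)[C@H]2OC1` with 3080 nM, and compound 3 `CCOc1ccc(NC2=CC(=O)c3c(nc4n3[C@H]3OC[C@@H](O)[C@H]3OC4)C2=O)cc1`. For compound 3 only a limit is known.

In a functional assay on ECa-109 cells for inhibition, with ECa-109 cell line (Homo sapiens) as the target, read by sulforhodamine B assay (a higher number here means a weaker inhibitor, a lower number a stronger inhibitor), compound 1 gives the lowest of the two numbers, and compound 2 lies within the scatter of it. Compound 3 reaches only > 4000 nM, a limit of the assay (the limit of > 4000 nM in this assay, at which 1 of the 3 values shown sits). Among the measured compounds shown here, the one measured step, an at least 1.2-fold higher number from compound 2 to compound 3 (0.11 log units; that floor lies within the scatter), swaps one aryl for another and therefore says little about the change to compound 4 `O=C1C=C(NC2CCCC2)C(=O)c2c1nc1n2[C@H]2OC[C@@H](O)[C@H]2OC1`, which is cyclopentyl in place of 4-iodophenyl on an amine nitrogen. For the measured compounds named here, no measured step replaces an aromatic ring with a saturated one, so the direction is open. Compound 4 is estimated at 3200 nM, between 1300 nM and 8000 nM, a step of a 1.4-fold higher number from compound 1 to compound 4 (0.14 log units; within the scatter) expected only as a guess.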

Compound 4, half-maximal inhibitory concentration: > 16000 nM
Compound 4 gave a limit, no number; the forecaster's own chance of this, stated with the estimate: 40%; middle value at least 5.0-fold (0.69 log units) away from the limit.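

Putting cyclopentyl on the amine nitrogen in place of 4-iodophenyl gives the only step shown that clearly lies beyond the scatter: in this assay it is an at least 6.9-fold higher number from compound 1 to compound 4 (0.84 log units; beyond the scatter). The reading for compound 4 is a limit and not a number: the limit of > 16000 nM in this assay, at which 1 of the 4 values shown sits. So, for this pair, the non-aromatic ring does not stand in for the aryl group at this position.

Compound 4 loses both the aromatic ring and the iodine, so the compounds shown leave open which of the two counts. Going by these compounds, a plain phenyl group would separate them, and how a benzyl group or a longer chain on this nitrogen would read also stays unknown.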